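The source may hold more compounds than are shown below. What is called first, only, known or untested is meant among the compounds shown, and "the series" means these compounds.

Compound 1 `COc1nc(C)c(CCO)c(OC)n1`: in a functional assay on HCT-116 cells (Homo sapiens) for antiproliferative activity, read by MTT assay, with a stated time of 24 h (on this read-out lower numbers stand for stronger inhibition and higher numbers for weaker inhibition), compound 1 gives > 100000 nM, a limit of the assay.
Compound 2 `COc1nc(Cl)nc(C)c1CCO`: in this assay compound 2 gives > 100000 nM, again a limit.
Compound 3 `COc1nc(C)c2c(n1)OCC2`: in this assay compound 3 gives > 100000 nM, also a limit.

All three values sit at the limit of > 100000 nM in this assay, at which 3 of the 3 values shown sit, so compound 2 cannot be placed relative to the others, and the step that the two limits leave unreadable from compound 1 to compound 2, chloro in place of methoxy on an aromatic carbon, stays unreadable. Compound 4 `COc1nc(Cl)nc(C)c1CCOC(C)=O` differs from compound 2 by acetyl in place of hydrogen on an oxygen on a saturated carbon: hydroxy to acetoxy, or hydroxymethyl to acetoxymethyl. Among the measured compounds shown here, no measured step touches this oxygen, so the data give no size or direction to expect in this assay beyond the scatter. Compound 4 is therefore expected to give 200000 nM, within 30000 nM to 1000000 nM, most likely again as a limit, which would make the expected step that the limit leaves unreadable from compound 2 to compound 4.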

Compound 4, half-maximal inhibitory concentration: > 100000 nM
Compound 4: no number, only a limit; the forecaster's own chance of this, stated with the estimate: 80%; the middle value lies beyond the limit too.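

Compound 2 and compound 4 both give only a limit, so the step between them cannot be read: the limit of > 100000 nM in this assay, at which 4 of the 4 values shown sit.
The compounds shown leave open whether any change to this shared core gives a readable value in this assay at all.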